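One Substituent Change, One Expected Read-out

The source may hold more compounds than are shown below. What is called first, only, known or untested is meant among the compounds shown, and "the series" means these compounds.

Compound 2 `CNC(=O)CCc1ccncc1-c1ccc2ccccc2c1` and compound 1 `CNC(=O)/C=C/c1ccncc1-c1ccc2c(cnn2C)c1` were both examined in an assay on a protein complex for inhibition of CDK8/Cyclin C (Homo sapiens), with a stated time of 1 h, tested at 10 uM; on this read-out lower numbers stand for less inhibition and higher numbers for more inhibition at the one concentration tested (going by the name of the read-out). In this assay compound 2 gives 100%, and compound 1 gives 98%; the two numbers lie within the scatter of each other, so neither is set apart. Compound 3 `CN(C)C(=O)/C=C/c1ccncc1-c1ccc2ccccc2c1` has not yet been measured. It differs from compound 2 by 2-(dimethylcarbamoyl)ethenyl in place of 2-(methylcarbamoyl)ethyl on an aromatic carbon. For the measured compounds named here, no step between measured compounds shows what this change does. Since compound 2 gives 100% near the top of the scale, compound 3 is expected to stay there, with a step of a number 5 percentage points lower from compound 2 to compound 3 (within the scatter) that is not beyond the scatter, an estimated 95% in the range 78% to 100%.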

Compound 3, a percentage reported as inhibition, at one concentration (the size of the read-out at that concentration, not a potency): 100%
The estimate for compound 3 lay 5 percentage points below the measured number; the range from low to high includes it.
By their numbers in this assay, from the lowest: compounds 1, 2 and 3 (each within the scatter of the next).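

For the compounds shown here, the step on this aromatic carbon, opposite the ring nitrogen, is the first one readable at this position: 2-(dimethylcarbamoyl)ethenyl in place of 2-(methylcarbamoyl)ethyl gives no change at the digits printed from compound 2 to compound 3 (within the scatter) in this assay at the one concentration tested. The read-out thus stays at the top of the scale when the amide hydrogen is lost and a double bond is gained in the same change. Nothing available here explains this result.

Each of these two differences remains unseparated from the other, since they occur together in this single step. Also open, as far as these compounds go, is how a carboxylic acid, an amine or a longer chain at this position would affect the read-out.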